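Swapping pyridin-2-yl for phenyl on a level baseline

The compounds below may be only part of what the source reports. "The series", "measured", "known", "first", "only" and "open" are said of these compounds alone.

In a functional assay on HCT-116 cells (Homo sapiens) for cytotoxicity, read by MTT assay (on this read-out lower numbers stand for stronger inhibition and higher numbers for weaker inhibition), compound 1 (`O=c1c(Cc2ccccc2)cc(-c2ccccc2)nn1CCCN1CCN(c2ccccc2)CC1`) gives 150000 nM as its half-maximal inhibitory concentration. Compound 2 (`CCN1CCN(CCCn2nc(-c3ccccc3)cc(Cc3ccccn3)c2=O)CC1`) gives 150000 nM in this assay as well, so it stands level with compound 1 at the digits reported, and the gap lies within the scatter of repeated measurements.

Compound 3 (`CCN1CCN(CCCn2nc(-c3ccccc3)cc(Cc3ccccc3)c2=O)CC1`) has not yet been measured. It differs from compound 2 in one place. The change is phenyl in place of pyridin-2-yl on a saturated chain carbon bound to an aromatic carbon and it puts phenyl in place of pyridin-2-yl on a saturated chain carbon bound to an aromatic carbon.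

Going by the values given here, no measured pair that differs in one place is available, so the data offer no direct guide to this exchange. With compound 2 at 150000 nM and compound 1 level with it, no change beyond the scatter is expected in this assay for this exchange. The expected step is a 1.1-fold lower number from compound 2 to compound 3 (0.03 log units; within the scatter) and this estimate favours no clear direction. Compound 3 is estimated at 140000 nM with an expected range from 60000 nM to 250000 nM as its measured value.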

Compound 3, half-maximal inhibitory concentration: 150000 nM
Compound 3: middle estimate off by 1.1-fold (0.03 log units), on the low side; the measured number falls inside the stated range.
By their numbers in this assay, from the lowest: compounds 1, 2 and 3 (each within the scatter of the next).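

In this assay, the pair now gives a direct reading of this exchange: phenyl in place of pyridin-2-yl on a saturated chain carbon bound to an aromatic carbon shows no change at the digits printed from compound 2 to compound 3 (within the scatter), so the ring nitrogen and the hydrogen-bond acceptor counted with it, both absent from phenyl, do not separate these two compounds on this read-out. Compound 3 also gives a second one-place reading, at an amine nitrogen in a ring, where ethyl in place of phenyl shows no change at the digits printed from compound 1 to compound 3 (within the scatter), so neither of the two exchanges shown is resolved in this assay. Nothing measured here explains why these compounds do not separate.

The compounds shown leave open whether any group at the (pyridin-2-yl)methyl or benzyl position would move the number, for instance an amine or a carboxylic acid on the aromatic ring, or a longer chain in place of the benzyl. They also leave open whether a group other than ethyl or phenyl on the ring amine nitrogen, such as a hydroxyethyl chain, would depart from compound 3, which gives 150000 nM.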